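Amide substituent variation on a shared core

This account rests on a few compounds, and the source may have more. Where it says the series, first, only, none or still open, it means among the compounds named here.

Three analogues built on one shared core differ only in the group attached to the carbonyl carbon of the amide. In a functional assay on cells for positive allosteric modulation of metabotropic glutamate receptor 5 (Rattus norvegicus), read by calcium flux (on this read-out higher numbers stand for an effect only at larger amounts of compound and lower numbers for an effect already at smaller amounts), compound 1 `O=C(Nc1cc(-c2ccccc2)nn1-c1ccccc1)c1cccc([N+](=O)[O-])c1` gives 39 nM, compound 2 `Cc1ccc(C(=O)Nc2cc(-c3ccccc3)nn2-c2ccccc2)cc1` gives 64 nM and compound 3 `O=C(Nc1cc(-c2ccccc2)nn1-c1ccccc1)c1ccc([N+](=O)[O-])cc1` gives 10.7 nM. Compound 3 stands at the lowest number of the three: the step of a 3.6-fold lower number from compound 1 to compound 3 (0.56 log units; beyond the scatter) and the step of a 6.0-fold lower number from compound 2 to compound 3 (0.78 log units; beyond the scatter) both go beyond the scatter, while a 1.6-fold higher number from compound 1 to compound 2 (0.22 log units; within the scatter) stays within it.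

Compound 4 `O=C(Nc1cc(-c2ccccc2)nn1-c1ccccc1)C1=CCCCC1` is not yet measured. It differs from compound 3 in that (cyclohex-1-en-1-yl in place of 4-nitrophenyl on a carbonyl carbon). The nearest measured precedents are the exchange of methyl for nitro, a 6.0-fold lower number from compound 2 to compound 3 (0.78 log units; beyond the scatter), and the move of the nitro group, a 3.6-fold lower number from compound 1 to compound 3 (0.56 log units; beyond the scatter); in both, the compound bearing the 4-nitrophenyl group gives the lower number. Going by the values given here, no measured step removes the aromatic ring itself, so that part of the change has no precedent here. The expected step of a 9.3-fold higher number from compound 3 to compound 4 (0.97 log units; beyond the scatter) is therefore towards a higher number in this assay, of a size comparable to or larger than these. For compound 4 the expected value is 100 nM, with a range from 30 nM to 400 nM.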

Compound 4, half-maximal effective concentration: 3300 nM
For compound 4 the middle estimate is 33-fold (1.52 log units) below the measured one; the measured number lies above the stated range.
By their numbers in this assay, from the lowest: compound 3; then compounds 1 and 2 (each within the scatter of the next); then compound 4.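

Cyclohex-1-en-1-yl on the carbonyl carbon is the first change here to give a large step, and it does so against all three aromatic amides: a 310-fold higher number from compound 3 to compound 4 (2.49 log units; beyond the scatter) and an 85-fold higher number from compound 1 to compound 4 (1.93 log units; beyond the scatter) and a 52-fold higher number from compound 2 to compound 4 (1.71 log units; beyond the scatter) in this assay. Each exceeds the widest step among those amides, a 6.0-fold lower number from compound 2 to compound 3 (0.78 log units; beyond the scatter), so the choice of substituent on the phenyl ring matters less at this position than keeping an aromatic ring there, at least among these four compounds. Nothing available bears on what lies behind this rise.

Going by these compounds, compound 4 removes the aromatic ring and its substituent in one change, so the share of each stays open. An unsubstituted phenyl or a pyridine ring would separate the two, and a saturated cyclohexyl group would test the ring double bond.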